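This account rests on a few compounds, and the source may have more. Where it says the series, first, only, none or still open, it means among the compounds named here.

Compound 1 `O=C(Nc1ccc(Oc2ccnc3[nH]ccc23)cc1)c1nn(-c2ccc(Cl)cc2)ccc1=O` gives 25100 nM in a functional assay on A549 cells (Homo sapiens) for cytotoxicity, read by MTT assay, with a stated time of 72 h; on this read-out higher numbers stand for weaker inhibition and lower numbers for stronger inhibition.
Compound 2 `O=C(Nc1ccc(Oc2ccnc3[nH]ccc23)c(F)c1)c1nn(-c2ccc(Cl)cc2)ccc1=O` reaches only the limit of this assay, reported as > 60000 nM.
Compound 3 `Cn1ccc2c(Oc3ccc(NC(=O)c4nn(-c5ccc(Cl)cc5)ccc4=O)cc3)ccnc21` likewise stops at the limit of this assay, reported as > 60000 nM.

Compound 3 therefore stands at the limit of > 60000 nM in this assay, at which 2 of the 3 values shown sit, and the numbers give no more than a floor for it; nothing shows how far beyond that floor it lies. The two measured steps both start from compound 1: an at least 2.3-fold higher number from compound 1 to compound 2 (0.37 log units; beyond the scatter), and an at least 2.3-fold higher number from compound 1 to compound 3 (0.37 log units; beyond the scatter). Each of them ends at the limit, so their true size is open at the top.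

The unmeasured compound 4 `Cn1ccc2c(Oc3ccc(NC(=O)c4nn(-c5ccc(Br)cc5)ccc4=O)cc3)ccnc21` differs from compound 3 in one place: bromo in place of chloro on an aromatic carbon. Neither of the measured steps touches this position or this kind of exchange; the fluoro and methyl changes sit elsewhere on the shared core, so they bear on it only in showing that the series as a whole sits weak in this assay. Among the measured compounds shown here, with no step on record for the halogen exchange, compound 4 is expected to stay close to compound 3, with a step that the limit leaves unreadable from compound 3 to compound 4 and no change beyond the scatter. Compound 4 is accordingly estimated at 80000 nM, within 30000 nM to 200000 nM, and most likely again reported only as a limit.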

Compound 4, half-maximal inhibitory concentration: 59400 nM
Beside the measured number, compound 4's estimate is 1.3-fold (0.13 log units) above it, within the range that was stated.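

In this assay, the exchange of 4-chlorophenyl for 4-bromophenyl is the first change shown at this position, an aromatic carbon para to a large group, and it brings a number no higher from compound 3 to compound 4 (the limit leaves the size open). Among the compounds shown that carry methyl on the aromatic nitrogen, compound 4 is the only one whose reading is a number and not a limit, at 59400 nM. Compound 3 is reported only as a limit, and the size of this step cannot be read because of that: the limit of > 60000 nM in this assay, at which 2 of the 4 values shown sit.

The compounds shown leave open how this position responds to groups other than the two halogens, such as a methoxy group, a nitrile or an amine, or to the removal of the halogen altogether. They also leave open whether bromo in place of chloro would give a readable step on the core of compound 1, which keeps hydrogen on the aromatic nitrogen and, unlike compound 3, has a value that is not a limit.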